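The compounds below may be only part of what the source reports. "The series", "measured", "known", "first", "only" and "open" are said of these compounds alone.

Measured compounds so far:

Compound 1 `CC(C)(C)OC(=O)N1CCC(O[C@H]2CC[C@H](Oc3ccc(C#N)cc3)CC2)CC1`, in a functional assay on isolated protein for agonist activity at Glucose-dependent insulinotropic receptor (Rattus norvegicus), read by HTRF and cAMP accumulation; a higher number here means a larger maximal response, a lower number a smaller maximal response: 106%.
Compound 2 `Cc1nc(S(C)(=O)=O)ccc1O[C@H]1CC[C@H](OC2CCN(C(=O)OC(C)C)CC2)CC1`, in this assay: 114%.
Compound 3 `C[C@H](CF)OC(=O)N1CCC(O[C@H]2CC[C@H](Oc3cnc(S(C)(=O)=O)cn3)CC2)CC1`, in this assay: 115%.

Compound 3 holds the highest of the three numbers, yet its nearest neighbour, compound 2, lies only a single percentage point below it, and even the furthest, compound 1, is nine points lower; both gaps fall within the usual scatter of the measurement, so the three compounds cannot be told apart on maximal response.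

Compound 4 `CS(=O)(=O)c1cnc(O[C@H]2CC[C@H](OC3CCN(CC4(C(F)(F)F)CC4)CC3)CC2)cn1` differs from compound 3 in one place: a group of 8 heavy atoms (5 carbon, 3 fluorine; one three-membered non-aromatic ring of carbon only) in place of a group of 7 heavy atoms (4 carbon, 2 oxygen, 1 fluorine; no ring), on an amine nitrogen in a ring. The carbamate of compound 3 is thus exchanged for an alkyl substituent on the ring nitrogen, and the two hydrogen-bond acceptors of the leaving group are lost.

Within the data shown here, no step between two measured compounds covers a change of this kind, so there is no measured guide to its effect in this assay. What the three measured compounds show is that the maximal response has not shifted beyond the scatter across a range of groups on this nitrogen. The expectation is therefore a step from compound 3 to compound 4 of a number 5 percentage points lower from compound 3 to compound 4 (within the scatter), that is, none beyond the scatter. Compound 4 is estimated to give 110%, expected between 95% and 125%.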

Compound 4, largest response reached (Emax), in percent of the reference or control that the assay uses: 124%
The estimate for compound 4 lay 14 percentage points below the measured number; the measured number falls inside the stated range.
By their numbers in this assay, from the lowest: compounds 1, 2, 3 and 4 (each within the scatter of the next, the first and the last beyond it).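

In this assay, replacing the carbamate on the ring nitrogen of compound 3 with (1-(trifluoromethyl)cyclopropyl)methyl gives a number 9 percentage points higher from compound 3 to compound 4 (within the scatter) and so leaves the maximal response unchanged within the scatter. Among these compounds, all the earlier compounds carried a carbamate on this nitrogen, so they could not show what compound 4 now shows: a full response at this position does not depend on the carbonyl or on the hydrogen-bond acceptors of the leaving group, and an alkyl substituent with a three-membered carbon ring and fluorine atoms is accepted there. The data offer no measured basis for explaining why the response holds across this exchange.

Going by these compounds, it remains open whether the cyclopropane ring or the trifluoromethyl group matters here, which a plain cyclopropylmethyl or a 2,2,2-trifluoroethyl group on the same nitrogen would help to separate. On these data alone, it is also open whether an amide, a urea or a sulfonamide on this nitrogen would keep the response, and the largest response reached says nothing about the concentration each compound needs to reach it.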